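Pyroglutamate Ester on the Beta-Lactone Core

The compounds below may be only part of what the source reports. "The series", "measured", "known", "first", "only" and "open" are said of these compounds alone.

Compound 1 `CCCCCCCCCCC[C@@H](C[C@@H]1OC(=O)[C@H]1CCCCCC)OC(=O)CNC(=O)OCc1ccccc1`: > 50000 nM
Compound 2 `CCCCCCCCCCC[C@@H](C[C@@H]1OC(=O)[C@H]1CCCCCC)OC(=O)[C@@H](NC(C)=O)C(C)CC`: 6600 nM

In an assay on membranes from brain for inhibition of Fatty-acid amide hydrolase 1 (Rattus norvegicus) (on this read-out lower numbers stand for stronger inhibition and higher numbers for weaker inhibition), compound 1 gives only a limit, > 50000 nM. Compound 2 gives 6600 nM, the one proper number shown. Among the compounds with values here, the single measured step, an at least 7.5-fold lower number from compound 1 to compound 2 (0.87 log units; beyond the scatter), rests on that limit (the limit of > 50000 nM in this assay, at which 1 of the 2 values shown sits). Compound 3 `CCCCCCCCCCC[C@@H](C[C@@H]1OC(=O)[C@H]1CCCCCC)OC(=O)[C@@H]1CCC(=O)N1` carries 5-oxopyrrolidin-2-yl in place of 1-acetamido-2-methylbutyl on a carbonyl carbon. Within the data shown here, that step is the only guide, and it covers a different exchange on the same carbonyl carbon, so the new change is expected to cost some of what it gained, giving a 3.0-fold higher number from compound 2 to compound 3 (0.48 log units; beyond the scatter). Compound 3 is therefore estimated at 20000 nM, between 5000 nM and 80000 nM.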

Compound 3, half-maximal inhibitory concentration: > 50000 nM
Compound 3: no number, only a limit; the forecaster's own chance of this, stated with the estimate: 40%; middle value at least 2.5-fold (0.39 log units) from the limit.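

In this assay, exchanging 1-acetamido-2-methylbutyl for 5-oxopyrrolidin-2-yl on this carbonyl carbon gives an at least 7.5-fold higher number from compound 2 to compound 3 (0.87 log units; beyond the scatter), so the gain seen with compound 2 does not carry over to this group. Compound 3 gives only a limit, > 50000 nM. The step between compound 1 and compound 3 cannot be read, and compound 2 remains the only one with a proper number: the limit of > 50000 nM in this assay, at which 2 of the 3 values shown sit.

On these data alone, how far compound 3 lies past its limit stays open. So does whether a free amine or a carboxylic acid on this carbonyl carbon would give a proper number.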